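Amide-chain amino alcohols: acylation of the amine and cytotoxicity

The compounds below may be only part of what the source reports. "The series", "measured", "known", "first", "only" and "open" are said of these compounds alone.

The series rests on a shared core with a long saturated chain on an amide-type nitrogen. Compound 1 `CCCCCCCCCCCCCCNC(=O)[C@@H](N)[C@@H](C)O` gives 10700 nM in a functional assay on MCF7 cells (Homo sapiens) for cytotoxicity, read by MTT assay, with a stated time of 48 h; on this read-out higher numbers stand for weaker inhibition and lower numbers for stronger inhibition. Compound 2 `CCCCCCCCCCCCCCCCCCNC(=O)[C@@H](N)[C@@H](C)O` gives 27400 nM, and compound 3 `CCCCCCCCCCCCCCNC(=O)[C@@H](NC(=O)c1cccs1)[C@@H](C)O` gives 36100 nM. Compound 2 thus holds the second highest of the three numbers: against compound 3 the gap is within the scatter, while the step of a 2.6-fold higher number from compound 1 to compound 2 (0.41 log units; beyond the scatter) lies beyond it.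

Compound 4 `CCCCCCCCCCCCCCCCCCNC(=O)[C@@H](NC(=O)/C=C/c1ccccc1)[C@@H](C)O` keeps the chain of compound 2 and differs from it in one place: (2-phenylethenyl)carbonyl in place of hydrogen on an amine nitrogen.

Among the measured compounds shown here, one measured step bears on this change. In compound 3 the same amine nitrogen carries a (thiophen-2-yl)carbonyl, and the step of a 3.4-fold higher number from compound 1 to compound 3 (0.53 log units; beyond the scatter) runs to a higher number. The (2-phenylethenyl)carbonyl group entering compound 4 is a different acyl group, but it too replaces hydrogen on that amine nitrogen, so a step of comparable size toward a higher number is the working expectation in this assay.

Compound 4 is therefore expected to give about 75000 nM, with a range from 30000 nM to 190000 nM. This expectation means a step of a 2.7-fold higher number from compound 2 to compound 4 (0.44 log units; beyond the scatter), modest, but beyond the scatter, carried over from the step seen for compound 3.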

Compound 4, half-maximal inhibitory concentration: 39200 nM
For compound 4 the middle estimate is 1.9-fold (0.28 log units) above the measured one, within the range that was stated.
By their numbers in this assay, from the lowest: compound 1; then compounds 2, 3 and 4 (each within the scatter of the next).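

On the chain of compound 2 in this assay, (2-phenylethenyl)carbonyl on the amine nitrogen gives a step that stays within the scatter (a 1.4-fold higher number from compound 2 to compound 4 (0.16 log units; within the scatter)), so acylation at this position does not carry a measurable penalty in this pair. Among the compounds shown here, the one earlier acylation step (a 3.4-fold higher number from compound 1 to compound 3 (0.53 log units; beyond the scatter)) lies beyond the scatter, so acylation of this nitrogen does not give a uniform outcome across the two pairs, although those pairs differ in both the acyl group and the chain on the amide-type nitrogen. No supporting measurement is available to account for this contrast.

From the compounds shown here alone, it remains open whether the contrast follows the acyl group or the chain, and placing (thiophen-2-yl)carbonyl on the chain of compound 2, or (2-phenylethenyl)carbonyl on the chain of compound 1, would separate the two. Going by these compounds, it is also open how an acetyl or a benzoyl group on the same amine nitrogen would read in this assay, which would show whether the result for compound 4 extends beyond this one acyl group.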